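Chain shortening from compound 1 to compound 4

The source may hold more compounds than are shown below. What is called first, only, known or untested is meant among the compounds shown, and "the series" means these compounds.

Measured so far in a physicochemical assay for lipophilicity, in phosphate buffer, measured as octanol-water partition, at pH 11.5 (on this read-out higher numbers stand for higher lipophilicity and lower numbers for lower lipophilicity), and nothing else
- compound 1 `CCCCC(CC)CNC(=N)NC(=N)Nc1ccc(Cl)cc1` gives 4.93
- compound 2 `CSc1ccc(NC(=N)NC(=N)NCCCCCCNC(=N)NC(=N)Nc2ccc(SC)cc2)cc1` gives 4.58
- compound 3 `CCCCCCS(=O)(=O)c1ccc(NC(=N)NC(=N)NCCCCCCNC(=N)NC(=N)Nc2ccc(S(=O)(=O)CCCCCC)cc2)cc1` gives 5.1

Compound 1 (4.93) lies within the scatter of compound 3 (5.1). Its distance to compound 2 (4.58) is beyond the scatter, with compound 1 the higher of those two. Among the three, only compound 1 carries a single biguanide-type unit and a chloro-substituted ring, so its value offers the only direct reference for the next compound.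

Compound 4 `CCCCNC(=N)NC(=N)Nc1ccc(Cl)cc1` is the next to be read. The change from compound 1 is hydrogen in place of butyl on a saturated chain carbon bound to two saturated chain carbons and, in words, hydrogen in place of butyl on a saturated chain carbon bound to two saturated chain carbons. The same difference can also be read as 1-ethylpentyl to propyl.

Among the measured compounds shown here, the series holds no measured step for this change, so its size rests on the structural difference alone. A lower number is expected, by a margin well beyond the scatter. The expected step is a number 1.63 log units lower from compound 1 to compound 4 (beyond the scatter) in this assay as an estimate. Compound 4 is estimated at 3.3 (expected range 2.7 to 3.9).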

Compound 4, partition coefficient: 3.13
Beside the measured number, compound 4's estimate is 0.17 log units above it, and the stated range covers the measured number.
By their numbers in this assay, from the lowest: compound 4; then compound 2; then compounds 1 and 3 (each within the scatter of the next).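

In this assay, the replacement of butyl by hydrogen on a saturated chain carbon bound to two saturated chain carbons gives the series its first measured step, a number 1.80 log units lower from compound 1 to compound 4 (beyond the scatter), and that step is large. Among the compounds shown here, earlier compounds offered no pair differing in one place, so no single structural change could be tied to a size on this read-out until now. Compound 1 and compound 4 share the rest of their structure, which places the whole step on this one difference, also readable as 1-ethylpentyl to propyl, and shows that this chain position can carry a change well beyond the scatter.

One step leaves open how the read-out runs through intermediate or larger groups at this place, such as a methyl, an ethyl or a longer chain like hexyl, and whether the change follows the carbon count evenly or not. It also leaves open whether a chain ending in a hydroxyl or an amine at the same place would fall on the same line, and whether the step keeps its size with a methoxy in place of the chloro on the ring. No available measurement bears on the cause of this step.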